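Cytotoxicity notes on a fused chromene pair

A few compounds are considered here, and "the series" means these few. Any claim that something is new, unique, unknown or untested is made for them only; others in the source may bear on it.

In an ADME assay on MCF-10A cells (Homo sapiens) for cytotoxicity, read by sulforhodamine B assay, with a stated time of 72 h, tested at 10 uM (a lower number here means a weaker effect, a higher number a stronger effect of the compound at the concentration tested), two compounds have been measured. Compound 1 `COc1cc(Br)cc(/C=C/C(=O)c2ccc(C)cc2)c1O` gives 155% in this assay. Compound 2 `COC(=O)C1=C(N)Oc2c(OC)cc(Br)cc2C1CC(=O)c1ccc(Cl)cc1` gives 40.9% in this assay, the lowest of the two numbers, and its nearest neighbour is compound 1, whose value is higher by a gap beyond the scatter. Within the data shown here, no pair of measured compounds differs in one place only, so no single-change step has been observed so far.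

Compound 3 `COc1cc(Br)cc2c1OC(N)=C(C#N)C2CC(=O)c1ccc(Cl)cc1` is not yet measured in this assay. It differs from compound 2 in one place: cyano in place of methoxycarbonyl on a double-bonded ring carbon. The change sits on a double-bonded ring carbon of the six-membered non-aromatic ring with one oxygen, part of the fused system of two rings, and the remaining parts of the molecule are unchanged.

Among the measured compounds shown here, there is no measured step that resembles this change, so the expectation rests on compound 2 alone. The step from compound 2 to compound 3 is expected to be small, of size a number 4.1 percentage points higher from compound 2 to compound 3 (within the scatter), with no clear direction beyond the scatter. Compound 3 is therefore expected to give about 45% in this assay, within a range from 20% to 80%.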

Compound 3, a percentage reported as activity, at one concentration (the size of the read-out at that concentration, not a potency): 36.8%
Estimate against measurement, compound 3: 8.2 percentage points above; measured number inside the range.
By their numbers in this assay, from the lowest: compounds 3 and 2 (each within the scatter of the next); then compound 1.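

In this assay, among these compounds, the exchange of methoxycarbonyl for cyano gives the first single-place step, a number 4.1 percentage points lower from compound 2 to compound 3 (within the scatter). On this double-bonded ring carbon, next to the ring atom that bears an amino group, the read-out at this concentration does not separate the two groups, so within this shared core the methoxycarbonyl is not needed for a number of this size, and a smaller cyano serves equally well. No measurement at hand bears on what lies behind this result.

The compounds shown leave open whether this tolerance holds for groups of another kind on the same carbon, such as a carboxylic acid, a primary amide or a longer ester chain, since two groups alone give no trend for the position. Among the compounds shown here, compound 1 differs from compound 2 and compound 3 in more than one place, so the single step here says nothing about which part of the structure accounts for the separate standing of compound 1.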